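Azide to amine on the oxazolidinone series

The source may hold more compounds than are shown below. What is called first, only, known or untested is meant among the compounds shown, and "the series" means these compounds.

Measured compounds:
compound 1, `NC[C@H]1CN(n2cccc2)C(=O)O1` — 4400 nM
compound 2, `[N-]=[N+]=NC[C@@H]1CN(n2cccc2)C(=O)O1` — 24000 nM

For the measured compounds named here, in an assay for inhibition of Amine oxidase [flavin-containing] B (Bos taurus) (a lower number here means a stronger inhibitor, a higher number a weaker inhibitor), compound 2 gives the highest of the two numbers so far; its nearest neighbour, compound 1, sits a clear distance below it, and that gap lies beyond the scatter of repeated measurements. Compound 3, `NC[C@@H]1CN(n2cccc2)C(=O)O1`, has not yet been measured in this assay. It differs from compound 2 in one place: amino in place of azido on a saturated chain carbon bound to a saturated ring carbon. Going by the values given here, no step between two measured compounds covers this exact exchange, so its size must be judged from what the two measured values show. Compound 1 also carries an aminomethyl group on the shared core and gives 4400 nM in this assay, which speaks for the amine being compatible with a lower number than the azide of compound 2. On that basis a step downward, beyond the scatter, is expected from compound 2 to compound 3, of the size a 4.0-fold lower number from compound 2 to compound 3 (0.60 log units; beyond the scatter). The estimate for compound 3 in this assay is 6000 nM, with a range from 1500 nM to 25000 nM.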

Compound 3, inhibition constant: 34000 nM
The estimate for compound 3 lay 5.7-fold (0.75 log units) below the measured number; measured number outside the range, above it.
By their numbers in this assay, from the lowest: compound 1; then compounds 2 and 3 (each within the scatter of the next).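

Working notes: in this assay, amino in place of azido on a saturated chain carbon bound to a saturated ring carbon, with the configuration as drawn unchanged, gives a 1.4-fold higher number from compound 2 to compound 3 (0.15 log units; within the scatter), so at this configuration the exchange leaves the two compounds indistinguishable. The presence of the aminomethyl group alone therefore does not account for the lower number of compound 1, as the same group in the opposite configuration gives a 7.7-fold higher number from compound 1 to compound 3 (0.89 log units; beyond the scatter), a modest but real separation. This places the difference between these two amines at the stereocentre on the saturated ring carbon, the only point at which they differ: the fact that compounds 1 and 3 differ only in the configuration as drawn

On these data alone, the dependence on configuration rests on a single pair, so whether it holds for azidomethyl, or for any other group at this position, remains open. Also open, as far as these compounds go, is how the configuration of compound 1 would respond to a hydroxymethyl or acetamidomethyl group in place of aminomethyl, and whether any such group would reach a lower number than the amine on the shared core.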